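This account rests on a few compounds, and the source may have more. Where it says the series, first, only, none or still open, it means among the compounds named here.

Measured in a functional assay on cells (Homo sapiens) for cytotoxicity, read by MTT assay, with a stated time of 24 h; a lower number here means a stronger inhibitor, a higher number a weaker inhibitor:
- Compound 1 (`CCCCCCCCCCCCCCNC(=O)[C@H](CO)/N=C/c1ccc(Cl)cc1`): 27500 nM
- Compound 2 (`CCCCCCCCCCCCCCNC(=O)[C@H](CO)/N=C/c1ccccc1`): 7670 nM

Compound 2 holds the lower of the two numbers, and its gap to compound 1 lies beyond the scatter. Compound 3 (`CCCCCCCCCCCCCCNC(=O)[C@H](CO)NCc1ccccc1Cl`) has not been measured yet. Its change from compound 2 is a group of 9 heavy atoms (7 carbon, 1 nitrogen, 1 chlorine; one six-membered aromatic ring of carbon only) in place of a group of 8 heavy atoms (7 carbon, 1 nitrogen; one six-membered aromatic ring of carbon only), on a saturated chain carbon bound to a carbonyl carbon and a saturated chain carbon. In it, (2-chlorobenzyl)amino enters on a saturated chain carbon bound to a carbonyl carbon and a saturated chain carbon.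

Among the compounds with values here, only one measured step bears on this: a 3.6-fold lower number from compound 1 to compound 2 (0.55 log units; beyond the scatter), with hydrogen in place of chloro on an aromatic carbon. Read in reverse, this modest step suggests that gaining a chlorine may raise the number. Within the data shown here, no measured pair shows the loss of the double bond outside aromatic rings, so that part remains open. A modest rise in this assay is therefore expected, with wide uncertainty. The estimated change is a 1.4-fold higher number from compound 2 to compound 3 (0.16 log units; within the scatter). Compound 3 is expected at 11000 nM, within an estimated range of 3500 nM to 35000 nM.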

Compound 3, half-maximal inhibitory concentration: 43700 nM
The estimate for compound 3 lay 4.0-fold (0.60 log units) below the measured number; measured number above the stated range.
By their numbers in this assay, from the lowest: compound 2; then compounds 1 and 3 (each within the scatter of the next).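

In this assay, placing (2-chlorobenzyl)amino on the saturated chain carbon bound to a carbonyl carbon and a saturated chain carbon gives a 5.7-fold higher number from compound 2 to compound 3 (0.76 log units; beyond the scatter), so this position responds to a change that combines a new chlorine, loss of the double bond outside aromatic rings and a new hydrogen-bond donor. The comparison of the two chlorine-bearing compounds gives a 1.6-fold higher number from compound 1 to compound 3 (0.20 log units; within the scatter), so replacing one chlorine-bearing group with the other produces no clear difference here. No measured evidence bears on the reason for either result.

The shown compounds cannot separate the contribution of the chlorine from that of the lost double bond. A plain benzylamino group, without chlorine, would split those two parts, while a fluoro in place of the chloro would test whether this halogen matters.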